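A few compounds are considered here, and "the series" means these few. Any claim that something is new, unique, unknown or untested is made for them only; others in the source may bear on it.

Compound 1 `Clc1ccc(-c2cc(-c3ccsc3)nc(-c3ccco3)c2)o1`: 18900 nM
Compound 2 `Clc1ccc(-c2cc(-c3ccco3)nc(-c3cccs3)c2)o1`: 21800 nM
Compound 3 `Clc1ccc(-c2cc(-c3ccoc3)cc(-c3cccs3)n2)cc1`: 21100 nM

In a functional assay on DU-145 cells (Homo sapiens) for cytotoxicity, in the presence of a further agent that is not named here (a lower number here means a stronger inhibitor, a higher number a weaker inhibitor), the three measured compounds lie within the scatter of one another, so compound 1 stands apart from neither compound 2 nor compound 3. Going by the values given here, the one measured step, a 1.2-fold higher number from compound 1 to compound 2 (0.06 log units; within the scatter), concerns a different change. Compound 4 `Clc1ccc(-c2cc(-c3ccsc3)nc(-c3ccccn3)c2)o1` is not yet measured. It differs from compound 1 by pyridin-2-yl in place of furan-2-yl on an aromatic carbon. Among the compounds with values here, no measured step bears on this exchange, and the only step available, from compound 1 to compound 2, is within the scatter. The expectation for compound 4 is therefore a number close to that of compound 1, with no step beyond the scatter. Compound 4 is expected to give about 19000 nM, in the range 7000 nM to 50000 nM. This corresponds to an expected step of a 1.0-fold higher number from compound 1 to compound 4 (0.00 log units; within the scatter).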

Compound 4, half-maximal inhibitory concentration: 10900 nM
Compound 4: the middle estimate sits 1.7-fold (0.24 log units) above what was measured, and the stated range covers the measured number.
By their numbers in this assay, from the lowest: compounds 4, 1, 3 and 2 (each within the scatter of the next).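

In this assay, pyridin-2-yl on the aromatic carbon next to the ring nitrogen gives a 1.7-fold lower number from compound 1 to compound 4 (0.24 log units; within the scatter). This position therefore accepts a six-membered aromatic ring in place of a five-membered one without a step beyond the scatter, whereas the earlier step covered only an exchange between two thiophene attachments. Nothing available here offers an explanation for this result. The compounds shown leave open how a phenyl group, a pyridin-3-yl group, an amine or a carboxylic acid at this position would compare in this assay.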